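The compounds below may be only part of what the source reports. "The series", "measured", "known", "first", "only" and "open" are said of these compounds alone.

Measured compounds:
Compound 1, `CC(C)(C)OC(=O)N1CCN(C(=S)SCc2cn(Cc3cc(=O)oc4cc(O)ccc34)nn2)CC1`. In a functional assay on ECa-109 cells (Homo sapiens) for inhibition, read by MTT assay, with a stated time of 72 h (on this read-out lower numbers stand for stronger inhibition and higher numbers for weaker inhibition), compound 1 gives only the assay limit > 128000 nM, not a number.
Compound 2, `Cc1ccc(Cn2cc(CSC(=S)N3CCN(C(=O)OC(C)(C)C)CC3)nn2)cc1`. In this assay compound 2 gives 47900 nM.
Compound 3, `Cc1ccc(-n2cc(CSC(=S)N3CCN(C(=O)OC(C)(C)C)CC3)nn2)cc1`. In this assay compound 3 gives 114000 nM.

Of the two numbers shown, compound 3 has the higher one, meaning weaker inhibition; its only neighbour is compound 2, and the step of a 2.4-fold higher number from compound 2 to compound 3 (0.38 log units; beyond the scatter) is modest but beyond the scatter. Compound 1 sits at the limit of > 128000 nM in this assay, at which 1 of the 3 values shown sits, and offers no number to compare.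

Compound 4, `CC(C)(C)OC(=O)N1CCN(C(=S)SCc2cn(Cc3ccccc3Cl)nn2)CC1`, differs from compound 3 in one place: 2-chlorobenzyl in place of 4-methylphenyl on an aromatic nitrogen. Among the measured compounds shown here, the one measured step that speaks to this is a 2.4-fold higher number from compound 2 to compound 3 (0.38 log units; beyond the scatter), where a benzyl group on the ring nitrogen was exchanged for a phenyl group and the number rose. Compound 4 brings a benzyl group back, now carrying a chlorine, so a step of roughly that size in the opposite direction is expected, that is a lower number than compound 3. Compound 1, with a different benzyl group, reaches only the limit, so the range stays wide.

For compound 4 the expected value in this assay is 50000 nM, between 20000 nM and 128000 nM. That estimate means a step of a 2.3-fold lower number from compound 3 to compound 4 (0.36 log units; beyond the scatter).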

Compound 4, half-maximal inhibitory concentration: 11900 nM
The estimate for compound 4 lay 4.2-fold (0.62 log units) above the measured number, outside the stated range (below it).
By their numbers in this assay, from the lowest: compound 4; then compound 2; then compound 3. At a limit, above all of these: compound 1.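

Among the compounds shown here, on the aromatic nitrogen of the five-membered ring, the 2-chlorobenzyl group gives the lowest number so far in this assay, with a 9.6-fold lower number from compound 3 to compound 4 (0.98 log units; beyond the scatter). Keeping the saturated chain carbon and changing only the group on it, 2-chlorophenyl in place of 4-methylphenyl, still gives a 4.0-fold lower number from compound 2 to compound 4 (0.60 log units; beyond the scatter), so this position responds to more than the presence of that chain carbon, which compound 2 and compound 3 alone could not show. Nothing shown explains why the number falls at this position.

Compound 1 gives only a limit: the limit of > 128000 nM in this assay, at which 1 of the 4 values shown sits. From the compounds shown here alone, it remains open whether the plain benzyl group, or an amine, a carboxylic acid or a longer chain in this place, would move the number further, and whether chlorine itself matters.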